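Moving the chlorine on the phenyl ring of compound 2

A few compounds are considered here, and "the series" means these few. Any claim that something is new, unique, unknown or untested is made for them only; others in the source may bear on it.

Measured compounds:
compound 1 `CS(=O)(=O)c1ccc2c(Cc3cccc(C(=O)O)n3)c(-c3ccccc3)nn2c1` — 5400 nM
compound 2 `O=C(O)c1cccc(Cc2c(-c3cccc(Cl)c3)nn3cc(Cl)ccc23)n1` — 480 nM

In a functional assay on cells for antagonist activity at prostaglandin E2 receptor EP1 subtype (Rattus norvegicus), read by fluorescence and calcium flux, with a stated time of 60 s (on this read-out higher numbers stand for weaker inhibition and lower numbers for stronger inhibition), compound 2 gives 480 nM, the lower of the two numbers. Compound 1, in the same this assay, gives 5400 nM, a higher number that lies beyond the scatter, so compound 2 is the stronger inhibitor of the pair. Compound 3 `O=C(O)c1cccc(Cc2c(-c3ccc(Cl)cc3)nn3cc(Cl)ccc23)n1` is built from compound 2 by a single change: 4-chlorophenyl in place of 3-chlorophenyl on an aromatic carbon. Going by the values given here, no measured pair shows this kind of move of a chlorine around the phenyl ring, so nothing here sets its size. He expects at most a modest step in this assay, in either direction, and most likely none beyond the scatter, since the two compounds share every atom and differ only in where the chlorine sits. Compound 3 is therefore estimated at 600 nM, with a range of 200 nM to 2000 nM, a step of a 1.3-fold higher number from compound 2 to compound 3 (0.10 log units; within the scatter) that is expected rather than known.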

Compound 3, half-maximal inhibitory concentration: 1100 nM
Beside the measured number, compound 3's estimate is 1.8-fold (0.26 log units) below it; the measured number falls inside the stated range.
By their numbers in this assay, from the lowest: compound 2; then compound 3; then compound 1.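

In this assay, where the chlorine sits on the phenyl ring makes a measurable difference: 4-chlorophenyl in place of 3-chlorophenyl gives a 2.3-fold higher number from compound 2 to compound 3 (0.36 log units; beyond the scatter), a modest step beyond the scatter, although no atom is gained or lost. Going by these compounds alone, the earlier compounds differ in more than one place, so this is the first change at this position whose size can be read, and here 3-chlorophenyl gives the lower number of the pair. Nothing measured here explains the difference between the two placements.

The compounds shown leave open whether a fluorine, a methyl or a methoxy group in place of the chlorine on the phenyl ring would follow the same order. They also leave open how the unsubstituted phenyl ring compares on the core of compound 2.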